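A few compounds are considered here, and "the series" means these few. Any claim that something is new, unique, unknown or untested is made for them only; others in the source may bear on it.

Measured so far in a functional assay on MONO-MAC-6 cells (Homo sapiens) for inhibition; on this read-out higher numbers stand for weaker inhibition and lower numbers for stronger inhibition:
compound 1, `C[C@@H](NS(=O)(=O)N1CC=C(c2ccc(Cl)cc2)CC1)C(=O)NO`: 1240 nM
compound 2, `O=C(NO)[C@H]1CCCCN1S(=O)(=O)N1CC=C(c2ccccc2)CC1`: 240 nM

In this assay compound 2 stands at the lowest of the two numbers in hand. Compound 1 sits at a higher number, and the gap between compound 1 and compound 2 lies beyond the usual scatter. The two differ in more than one place, so no single step can be read from them.

Compound 3, `O=C(NO)[C@H]1CCCCN1S(=O)(=O)N1CC=C(c2ccc(Br)cc2)CC1`, is the next candidate and is not yet measured in this assay. Compound 3 differs from compound 2 in one place: bromo in place of hydrogen on an aromatic carbon.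

For the measured compounds named here, no measured step of this kind exists, so the expectation for this assay rests on compound 2 alone. The change is small in what it adds, and the expected step is a modest move toward a lower number, near the edge of the scatter rather than clearly beyond it. Compound 3 is therefore estimated at 150 nM, with a range from 50 nM to 500 nM. The step this estimate implies is a 1.6-fold lower number from compound 2 to compound 3 (0.20 log units; within the scatter).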

Compound 3, half-maximal inhibitory concentration: 1200 nM
The estimate for compound 3 lay 8.0-fold (0.90 log units) below the measured number, and the stated range ends below it.
By their numbers in this assay, from the lowest: compound 2; then compounds 3 and 1 (each within the scatter of the next).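

In this assay, for the compounds shown here, bromo in place of hydrogen on the aromatic carbon para to a large group gives a 5.0-fold higher number from compound 2 to compound 3 (0.70 log units; beyond the scatter), the first one-place step. It shows that this carbon is not neutral to substitution: one added bromine, with no ring, no hydrogen-bond donor or acceptor and no net charge, is enough to weaken inhibition beyond the scatter. Nothing in hand explains the size of this step.

One group at one carbon cannot show whether the loss belongs to bromo itself or to any group placed there. Fluoro, methoxy or an amine at the same carbon would separate these cases, and a hydrogen-to-bromo step on a second parent compound would show whether the loss carries over.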